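The source may report more compounds than this note shows. Statements on the series, on what has been measured and on what is new or still open speak of the compounds shown alone.

Measured so far in the series:
compound 1 `CC1(/N=C(\NC#N)Nc2cccnc2)CCC1` — 50 mg/kg
compound 2 `N#CN/C(=N\CC1CCCO1)Nc1cccnc1` — 50 mg/kg

In a functional assay on the whole organism (blood, strain Wistar-Okamoto) with Rattus norvegicus as the target, with a stated time of 5 days (on this read-out lower numbers stand for an effect already at smaller amounts and higher numbers for an effect only at larger amounts of compound), compound 1 gives 50 mg/kg, and compound 2 gives 50 mg/kg. Among the compounds with values here, the one measured step, no change at the digits printed from compound 1 to compound 2 (within the scatter), shows that exchanging the group on the double-bonded nitrogen left the read-out where it was. Compound 2 therefore stands level with compound 1 at the digits shown, with compound 1 as its only neighbour.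

Compound 3 `N#CN/C(=N\c1ccccc1)Nc1cccnc1` is the next member. Its change from compound 2 is phenyl in place of (oxolan-2-yl)methyl on a double-bonded nitrogen. Within the data shown here, the only step that bears on this position is the one from compound 1 to compound 2, which was without change beyond the scatter; no measured pair exchanges the (oxolan-2-yl)methyl for phenyl, so the expectation rests on that single step alone. A step of no real size in this assay is expected, no change at the digits printed from compound 2 to compound 3 (within the scatter). For compound 3 the estimated minimum effective dose is 50 mg/kg, within the range 15 mg/kg to 150 mg/kg.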

Compound 3, minimum effective dose: 5 mg/kg
Compound 3: middle estimate off by 10-fold (1.00 log units), on the high side; the whole stated range lies above it.
By their numbers in this assay, from the lowest: compound 3; then compounds 1 and 2 (each within the scatter of the next).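

In this assay the substituent on the double-bonded nitrogen is not indifferent: phenyl gives a 10-fold lower number from compound 2 to compound 3 (1.00 log units; beyond the scatter) and a 10-fold lower number from compound 1 to compound 3 (1.00 log units; beyond the scatter) at this place, whereas the exchange among the two non-aromatic groups gave no change at the digits printed from compound 1 to compound 2 (within the scatter) there. Phenyl and (oxolan-2-yl)methyl hold the same count of heavy atoms, so a step of this size appears here without any difference in that count, and compound 3 alone of the three carries an aromatic ring of carbon on this nitrogen. Nothing at hand explains the step.

As far as these compounds go, whether the lower number belongs to the aromatic ring itself or to phenyl in particular stays open. Cyclohexyl, benzyl, pyridyl or chlorophenyl on the same nitrogen would bear on that question.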